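The source may report more compounds than this note shows. Statements on the series, on what has been measured and on what is new or still open speak of the compounds shown alone.

Working notes on the series. The three measured compounds share one core and differ only in the group on the saturated ring carbon. Compound 1 `N#Cc1cnc(NCc2cnccc2C(F)(F)F)cc1N[C@H]1CC[C@@H](O)CC1` carries a hydroxy there and in an assay on isolated protein for inhibition of protein kinase C delta type (Homo sapiens), read by TR-FRET, with a stated time of 2 h (on this read-out higher numbers stand for weaker inhibition and lower numbers for stronger inhibition), compound 1 gives 4500 nM. Compound 2 `N#Cc1cnc(NCc2cnccc2C(F)(F)F)cc1N[C@H]1CC[C@@H](C(N)=O)CC1` carries a carbamoyl and gives 400 nM. Compound 3 `CNC(=O)[C@H]1CC[C@@H](Nc2cc(NCc3cnccc3C(F)(F)F)ncc2C#N)CC1` carries a methylcarbamoyl and gives 1600 nM, the second highest of the three numbers; the steps run an 11-fold lower number from compound 1 to compound 2 (1.05 log units; beyond the scatter), a 2.8-fold lower number from compound 1 to compound 3 (0.45 log units; beyond the scatter) and a 4.0-fold higher number from compound 2 to compound 3 (0.60 log units; beyond the scatter). Compound 4 `CN(C)C(=O)[C@H]1CC[C@@H](Nc2cc(NCc3cnccc3C(F)(F)F)ncc2C#N)CC1` differs from compound 3 by methyl in place of hydrogen on an amide-type nitrogen, methylcarbamoyl to dimethylcarbamoyl. Going by the values given here, the only step that bears on this is a 4.0-fold higher number from compound 2 to compound 3 (0.60 log units; beyond the scatter), a methyl on the same amide-type nitrogen, modest and toward a higher number. A further modest rise is therefore expected, a 2.2-fold higher number from compound 3 to compound 4 (0.34 log units; beyond the scatter). For compound 4 the estimate is 3500 nM, within 1200 nM to 10000 nM.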

Compound 4, half-maximal inhibitory concentration: 1800 nM
For compound 4 the middle estimate is 1.9-fold (0.29 log units) above the measured one; the measured number falls inside the stated range.
By their numbers in this assay, from the lowest: compound 2; then compounds 3 and 4 (each within the scatter of the next); then compound 1.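

Going by these compounds alone, the second methyl on the amide-type nitrogen adds nothing that can be read (a 1.1-fold higher number from compound 3 to compound 4 (0.05 log units; within the scatter)), whereas the first gave a step beyond the scatter (a 4.0-fold higher number from compound 2 to compound 3 (0.60 log units; beyond the scatter)). Dimethylcarbamoyl thus stays apart from carbamoyl (a 4.5-fold higher number from compound 2 to compound 4 (0.65 log units; beyond the scatter)) and from hydroxy (a 2.5-fold lower number from compound 1 to compound 4 (0.40 log units; beyond the scatter)), so at this position only the unsubstituted carbamoyl gives the lowest number. No measurement at hand accounts for these numbers.

Open, as far as these compounds go, is how a carboxylic acid or an amine on the same saturated ring carbon would read in this assay. Also open, from the compounds shown here alone, is whether an ethyl or longer chain on the amide-type nitrogen would match methyl.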